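The source may hold more compounds than are shown below. What is called first, only, known or untested is meant among the compounds shown, and "the series" means these compounds.

Measured so far in an ADME assay on microsomes from liver (Homo sapiens) for metabolic stability, read by HPLC, using NADPH, with a stated time of 60 min, tested at 1 uM, in the presence of a further agent that is not named here; on this read-out lower numbers stand for slow clearance and higher numbers for fast clearance:

compound 1 `O=C(NNS(=O)(=O)c1ccccc1F)c1cc(F)cc(-n2cccn2)c1` gives 18 uL/min
compound 2 `O=C(NNS(=O)(=O)c1ccccc1F)c1cc(F)cc(-c2ccccn2)c1` gives 31 uL/min
compound 3 `Cc1cc(-c2ncccn2)cc(C(=O)NNS(=O)(=O)c2ccccc2)c1F` gives 11 uL/min

Compound 2 holds the highest of the three numbers in this assay. Its nearest neighbour is compound 1, and the step of a 1.7-fold higher number from compound 1 to compound 2 (0.24 log units; within the scatter) lies within the scatter, so the two are not separated. Going by the values given here, compound 3 stands furthest from compound 2, with a gap that is beyond the scatter; no single-point step connects compound 3 to the others, so only the two values themselves can be compared.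

The next compound, compound 4 `C=CCOc1cc(F)cc(C(=O)NNS(=O)(=O)c2ccccc2F)c1`, is not yet measured in this assay. Its change from compound 2 is allyloxy in place of pyridin-2-yl on an aromatic carbon

Among the compounds with values here, only one measured step exists, the one from compound 1 to compound 2, and it concerns a different exchange at the same position; it was small and within the scatter. Nothing measured here speaks to an allyloxy group. The expectation for compound 4 therefore rests on compound 2 alone, with no basis for a directional shift beyond the scatter: the step of a 1.1-fold higher number from compound 2 to compound 4 (0.03 log units; within the scatter) is expected to stay within the usual spread. Compound 4 is estimated at 33 uL/min, with a range from 14 uL/min to 75 uL/min.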

Compound 4, intrinsic clearance in a liver preparation (reported as CLH), per the amount of preparation that the assay uses: 138 uL/min
Compound 4: the middle estimate sits 4.2-fold (0.62 log units) below what was measured; the measured number lies above the stated range.
By their numbers in this assay, from the lowest: compounds 3, 1 and 2 (each within the scatter of the next, the first and the last beyond it); then compound 4.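

In this assay, this position, meta to a fluoro group on the shared core, proves able to move the read-out, which the exchange of one aromatic ring for another did not show: that exchange gave only a 1.7-fold higher number from compound 1 to compound 2 (0.24 log units; within the scatter). Allyloxy, which carries no ring, gives a 4.5-fold higher number from compound 2 to compound 4 (0.65 log units; beyond the scatter) and, against the pyrazole, a 7.7-fold higher number from compound 1 to compound 4 (0.88 log units; beyond the scatter), so both aromatic groups stand apart from it beyond the scatter, and the series now holds a real difference at this place. No measurement at hand bears on why the number rises with this change.

The three compounds with this core leave open which feature of allyloxy goes with the higher number: the ether oxygen, the double bond outside aromatic rings, or the absence of a ring. A saturated propoxy chain, a methoxy group or a benzyloxy group at the same place would separate these readings, and whether any of them stays close to the pyrazole and pyridine compounds remains an open question for the series.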